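The compounds below may be only part of what the source reports. "The series", "measured", "known", "first", "only" and "open" are said of these compounds alone.

Measured in a functional assay on K562 cells (Homo sapiens) for cytotoxicity, read by trypan blue exclusion, with a stated time of 96 h (a lower number here means a stronger inhibitor, a higher number a weaker inhibitor), so far:

- Compound 1 (`O=S(=O)(/C=C/c1ccccc1)Nc1ccccc1`) gives 10000 nM here
- Compound 2 (`COc1ccc(NS(=O)(=O)/C=C/c2c(F)c(F)c(F)c(F)c2F)cc1F`) gives 10000 nM here

Compound 2 stands level with compound 1, and the two values lie within the scatter. Compound 3 (`COc1ccc(NS(=O)(=O)/C=C/c2c(F)c(F)c(F)c(F)c2F)cc1`) differs from compound 2 in one place: hydrogen in place of fluoro on an aromatic carbon with hydrogen in place of fluoro on an aromatic carbon. Among the compounds with values here, no measured step shows what this exchange does. In this assay, within the data shown here, no change beyond the scatter is expected, in either direction, and the only guide is compound 2 at 10000 nM in that read-out. The expected 1.3-fold lower number from compound 2 to compound 3 (0.10 log units; within the scatter) stays within the scatter. Expected for compound 3 is 8000 nM with an estimated range from 1500 nM to 15000 nM in this read-out.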

Compound 3, half-maximal inhibitory concentration: 5000 nM
The estimate for compound 3 lay 1.6-fold (0.20 log units) above the measured number, within the range that was stated.
By their numbers in this assay, from the lowest: compounds 3, 1 and 2 (each within the scatter of the next).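

Exchanging the fluoro ortho to a methoxy group for hydrogen gives, in this assay, a 2.0-fold lower number from compound 2 to compound 3 (0.30 log units; within the scatter). Within the data shown here, this is the only reading of the exchange so far, and it shows that hydrogen is tolerated at this position without a change beyond the scatter. No supporting measurement bears on this step.

From the compounds shown here alone, whether an amine, a chloro or a methyl group at this position would move the number beyond the scatter remains open. Also open is what the methoxy group itself contributes, as no pair shown isolates it.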